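A shorter side chain at the cytotoxicity limit

This account rests on a few compounds, and the source may have more. Where it says the series, first, only, none or still open, it means among the compounds named here.

Compound 1 `CCC(CC)Nc1cc(Oc2c(OC)cc3cc(C#N)ccc3c2OC)nc(Nc2ccc(C#N)cc2)n1` gives > 125000 nM as a limit
Compound 2 `CCCC(C)Nc1cc(Oc2c(OC)cc3cc(C#N)ccc3c2OC)nc(Nc2ccc(C#N)cc2)n1` gives > 125000 nM as a limit
Compound 3 `COc1cc2cc(C#N)ccc2c(OC)c1Oc1cc(NCCCOC(C)C)nc(Nc2ccc(C#N)cc2)n1` gives > 125000 nM as a limit

All three results come from an ADME assay on MT4 cells (Homo sapiens) for cytotoxicity, read by MTT assay, with a stated time of 5 days (on this read-out lower numbers stand for higher toxicity in this test and higher numbers for lower toxicity in this test), and each is a limit of the assay, not a number. Compound 3 stands at > 125000 nM which is a limit. It shares that place with the others, as the limit of > 125000 nM in this assay, at which 3 of the 3 values shown sit, shows.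

Compound 4 `COc1cc2cc(C#N)ccc2c(OC)c1Oc1cc(NCC2CC2)nc(Nc2ccc(C#N)cc2)n1` is still unmeasured. It differs from compound 3 only in the side chain, as cyclopropyl in place of 2-isopropoxyethyl on a saturated chain carbon bound to a nitrogen on an aromatic ring sets out, with cyclopropyl in place of 2-isopropoxyethyl on a saturated chain carbon bound to a nitrogen on an aromatic ring.

The closest evidence comes from three measured swaps of the group on that nitrogen. They are a step that the two limits leave unreadable from compound 1 to compound 2 and a step that the two limits leave unreadable from compound 1 to compound 3 and also a step that the two limits leave unreadable from compound 2 to compound 3 so none of them has a size that can be read. All three chains tested so far reach the limit, and none goes against that. A value under the limit remains possible for a new chain, but nothing measured points to one.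

In this assay the expected change is a number no higher from compound 3 to compound 4 (the limit leaves the size open) with no direction expected beyond the scatter. Compound 4 is estimated at 125000 nM with an expected range from 60000 nM to 250000 nM and will most likely be reported as a limit again.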

Compound 4, half-maximal cytotoxic concentration: > 125000 nM
Compound 4 gave a limit, no number (the forecaster's own chance of this, stated with the estimate: 75%); the middle value lies on the limit itself.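

No step from compound 1, compound 2 or compound 3 to compound 4 can be read, because all four compounds give a limit and not a number: the limit of > 125000 nM in this assay, at which 4 of the 4 values shown sit.

The compounds shown leave open whether any other chain on this nitrogen would give a value under that limit, and how far these four compounds truly differ.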